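Swapping a cycloheptyl for a difluorophenyl on the ring nitrogen

The source may report more compounds than this note shows. Statements on the series, on what has been measured and on what is new or still open speak of the compounds shown alone.

Measured compounds:
compound 1 `Nc1scc(CN2CCN(c3ccc([N+](=O)[O-])cc3)CC2)c1C(=O)c1ccc(Cl)cc1`: -13%
compound 2 `Nc1scc(CN2CCN(c3ccc(OC(F)(F)F)cc3)CC2)c1C(=O)c1ccc(Cl)cc1`: -13%
compound 3 `Nc1scc(CN2CCN(C3CCCCCC3)CC2)c1C(=O)c1ccc(Cl)cc1`: 13%

All three share one core and differ only in the group on the amine nitrogen in the ring. In a functional assay on CHO cells with adenosine receptor A1 (Homo sapiens) as the target, read by cAMP accumulation and immunoassay, with a stated time of 6 min, tested at 0.1 uM (on this read-out higher numbers stand for a weaker effect at the one concentration tested and lower numbers for a stronger effect), compound 1 gives -13% and compound 2 gives -13%; the step of no change at the digits printed from compound 1 to compound 2 (within the scatter) shows that exchanging one substituent on the aromatic ring for another left the read-out unchanged. Compound 3 stands highest of the three, with 13% in this assay; its steps of a number 26 percentage points higher from compound 1 to compound 3 (beyond the scatter) and a number 26 percentage points higher from compound 2 to compound 3 (beyond the scatter) both lie beyond the scatter.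

Compound 4 `Nc1scc(CN2CCN(c3cccc(F)c3F)CC2)c1C(=O)c1ccc(Cl)cc1` is not yet measured. Compared with compound 3 it differs in one place: 2,3-difluorophenyl in place of cycloheptyl on an amine nitrogen in a ring. This is the reverse of the steps from compounds 1 and 2 to compound 3, in which a cycloheptyl replaced an aromatic ring on that nitrogen and raised the number. Returning to an aromatic ring is therefore expected to lower the number by a similar amount, as a number 26 percentage points lower from compound 3 to compound 4 (beyond the scatter), and compound 4 is estimated at -13%, within -30% to 5%.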

Compound 4, a percentage reported as activity, at one concentration (the size of the read-out at that concentration, not a potency): -5.2%
Compound 4: the middle estimate sits 7.8 percentage points below what was measured; the range from low to high includes it.
By their numbers in this assay, from the lowest: compounds 1, 2 and 4 (each within the scatter of the next); then compound 3.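

In this assay, the return to an aromatic ring on the ring nitrogen gives a number 18.2 percentage points lower from compound 3 to compound 4 (beyond the scatter), so a third aromatic group, this time carrying two fluorines, also falls on the lower side of the cycloheptyl compound. The earlier compounds did not show that the kind of substituent matters so little among these aromatic rings: 2,3-difluorophenyl gives a number 7.8 percentage points higher from compound 2 to compound 4 (within the scatter) and a number 7.8 percentage points higher from compound 1 to compound 4 (within the scatter), leaving compounds 1, 2 and 4 indistinguishable in this read-out. No measurement available here explains the difference between the aromatic rings and the cycloheptyl.

With only one non-aromatic ring shown, it remains open whether a cyclopentyl or a butyl chain on that nitrogen would match compound 3 or compounds 1, 2 and 4. Readings at a single concentration also leave potency itself open.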